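Propargyloxy to 2-ethoxyethoxy on a shared dichloroaniline core

The source may hold more compounds than are shown below. What is called first, only, known or untested is meant among the compounds shown, and "the series" means these compounds.

Measured so far:
compound 1 `CCO/N=C/Nc1cc(Cl)c([S+]([O-])CC)c(Cl)c1`: 2.9
compound 2 `CCO/N=C/Nc1cc(Cl)c(OCCCl)c(Cl)c1`: 4
compound 3 `C#CCO/N=C/Nc1cc(Cl)c(CC#C)c(Cl)c1`: 3.3

In a physicochemical assay for lipophilicity, measured as octanol-water partition (on this read-out lower numbers stand for lower lipophilicity and higher numbers for higher lipophilicity), compound 3 stands second highest of the three, with compound 1 lying below it and compound 2 lying above it, both gaps beyond the scatter. Compound 4 `C#CCc1c(Cl)cc(N/C=N/OCCOCC)cc1Cl` differs from compound 3 in one place: ethoxymethyl in place of ethynyl on a saturated chain carbon bound to an oxygen on an unsaturated carbon. For the measured compounds named here, no measured step touches this position. Going by the values given here, the only step on record, a number 1.10 log units higher from compound 1 to compound 2 (beyond the scatter), concerns a different group on the aromatic ring and says nothing direct about the oxime chain. Among the compounds with values here, with no step to lean on, and ethoxymethyl bringing more carbon but also an ether oxygen, compound 4 is expected to sit close to compound 3, perhaps a little higher, at 3.5, between 3 and 4, a step of a number 0.20 log units higher from compound 3 to compound 4 (within the scatter) that may lie within the scatter.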

Compound 4, partition coefficient: 3.7
Beside the measured number, compound 4's estimate is 0.20 log units below it; measured number inside the range.
By their numbers in this assay, from the lowest: compound 1; then compound 3; then compounds 4 and 2 (each within the scatter of the next).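

In this assay, for the compounds shown here, the change from propargyloxy to 2-ethoxyethoxy gives a number 0.40 log units higher from compound 3 to compound 4 (beyond the scatter), the first step on record at this position. The only earlier step concerned a group on an aromatic carbon, so this position is now shown to move the number, and it does so upward even though the entering ethoxymethyl carries an ether oxygen. Nothing available explains this step. Open, on these data alone, is whether a longer chain, or an amine in place of the ether oxygen, would continue the same trend, and whether the step would hold with a different group on the aromatic carbon.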